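Chloro for iodo on the shared core: working notes

A few compounds are considered here, and "the series" means these few. Any claim that something is new, unique, unknown or untested is made for them only; others in the source may bear on it.

Of the compounds shown here, three of the shared core have been tested in a functional assay on OVCAR-3 cells (Homo sapiens) for cytotoxicity, read by MTT assay, with a stated time of 6 days; on this read-out lower numbers stand for stronger inhibition and higher numbers for weaker inhibition. Compound 1 `CC(=O)N[C@@H](CSC(=O)NCc1ccc(Cl)cc1)C(=O)O` gives only a limit of the assay, > 200000 nM. Compound 2 `CC(=O)N[C@@H](CSC(=O)Nc1ccc(I)cc1)C(=O)O` likewise gives only a limit, > 200000 nM. Compound 3 `COc1ccccc1NC(=O)SC[C@H](NC(C)=O)C(=O)O` also gives only a limit, > 200000 nM. Among the measured compounds shown here, compound 2 therefore stands at the limit of > 200000 nM in this assay, at which 3 of the 3 values shown sit, and no step between measured compounds can be sized from these numbers. Compound 4 `CC(=O)N[C@@H](CSC(=O)Nc1ccc(Cl)cc1)C(=O)O` differs from compound 2 by chloro in place of iodo on an aromatic carbon. In this assay no shift beyond the usual scatter is expected for this change. Compound 4 is estimated at 200000 nM, with a range from 100000 nM to 400000 nM. The step of a number no higher from compound 2 to compound 4 (the limit leaves the size open) is expected to be essentially none, most likely again a limit rather than a number.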

Compound 4, half-maximal inhibitory concentration: > 200000 nM
Compound 4: only a limit was reported; the forecaster's own chance of this, stated with the estimate: 85%; the middle value lies on the limit itself.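

In this assay, among the compounds shown here, compound 4 gives only a limit, > 200000 nM, so no step from compound 2 to compound 4 can be read. The compounds shown leave open whether any change on the shared core gives a readable value: the limit of > 200000 nM in this assay, at which 4 of the 4 values shown sit.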